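The source may hold more compounds than are shown below. What is called first, only, known or untested is meant among the compounds shown, and "the series" means these compounds.

Compound 1 `CC(O)n1cnc2c(Cl)nc(I)nc21`, compound 2 `CC(O)n1cnc2c(N)nc(I)nc21` and compound 3 `Nc1nc(I)nc2c1ncn2OCCO` share one core and differ in one place at a time. In a functional assay on HT-29 cells (Homo sapiens) for inhibition (on this read-out lower numbers stand for stronger inhibition and higher numbers for weaker inhibition), compound 1 gives > 500000 nM, which is a limit of the assay and not a number. In this assay compound 2 gives > 500000 nM, again a limit. In this assay compound 3 gives > 500000 nM, also a limit. All three values sit at the limit of > 500000 nM in this assay, at which 3 of the 3 values shown sit, so compound 3 stands at the edge of what this assay reports, with no number to place it against the others. The step that the two limits leave unreadable from compound 1 to compound 2 and the step that the two limits leave unreadable from compound 2 to compound 3 are therefore both of unreadable size. Compound 4 `COc1nc(I)nc2c1ncn2OCCO` differs from compound 3 by methoxy in place of amino on an aromatic carbon. Among the compounds with values here, no measured step touches this exchange, and the two that exist give no size at all, so nothing beyond the scatter can be foreseen in any direction. Compound 4 is expected to give 500000 nM in this assay, with a range from 100000 nM to 2000000 nM. The expected step is a number no higher from compound 3 to compound 4 (the limit leaves the size open), that is, no change that the assay would resolve.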

Compound 4, half-maximal inhibitory concentration: > 500000 nM
Compound 4 ended at the assay's limit (the forecaster's own chance of this, stated with the estimate: 85%); the middle value lies on the limit itself.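

Compound 3 and compound 4 both stand at a limit of this assay, so no size can be read for the exchange of amino for methoxy: the limit of > 500000 nM in this assay, at which 4 of the 4 values shown sit.

The compounds shown leave open whether any change on the shared core brings a measurable value in this assay.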